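Iodo to bromo in a small halogen series

The source may hold more compounds than are shown below. What is called first, only, known or untested is meant among the compounds shown, and "the series" means these compounds.

Compound 1 `Nc1ccc(-c2nc3cc(F)ccc3s2)cc1Cl`: 40 nM
Compound 2 `Nc1ccc(-c2nc3cc(F)ccc3s2)cc1I`: 130 nM

In a functional assay on T47D cells (Breast, Homo sapiens) for inhibition (a lower number here means a stronger inhibitor of growth, a higher number a weaker inhibitor of growth), compound 2 has the higher of the two numbers, which makes it the weaker inhibitor of growth, and its gap to compound 1 lies beyond the scatter. Compound 3 `Nc1ccc(-c2nc3cc(F)ccc3s2)cc1Br` keeps the shared core and alters one group: bromo in place of iodo on an aromatic carbon. Among the compounds with values here, the one measured step bearing on this is a 3.3-fold higher number from compound 1 to compound 2 (0.51 log units; beyond the scatter), a modest step for iodo in place of chloro. The change here runs the opposite way along the halogens, so a smaller step toward a lower number is expected in this assay, although no bromo result exists yet to confirm this. The expected step is a 1.9-fold lower number from compound 2 to compound 3 (0.27 log units; within the scatter). Compound 3 is estimated at 70 nM, with an expected range of 30 nM to 160 nM.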

Compound 3, concentration for 50% growth inhibition: 20 nM
Estimate against measurement, compound 3: 3.5-fold (0.54 log units) above; the whole stated range lies above it.
By their numbers in this assay, from the lowest: compounds 3 and 1 (each within the scatter of the next); then compound 2.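

In this assay there is a 6.5-fold lower number from compound 2 to compound 3 (0.81 log units; beyond the scatter) on going from iodo to bromo on this aromatic carbon, ortho to an amino group, so the earlier penalty for iodo is not shared by every heavier halogen at this position. With a 2.0-fold lower number from compound 1 to compound 3 (0.30 log units; within the scatter) in the same assay, bromo and chloro cannot be told apart, and among the three halogens only the iodo compound 2 stands apart from the other two. Nothing measured here explains why iodo differs from the two smaller-numbered halogens.

The compounds shown leave open how hydrogen, fluoro, methyl or a nitrile would read at this carbon. They also leave open whether the same halogen pattern would hold with an acetamide in place of the amino group.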